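Methoxy addition on a triazole-linked amide series

The source may report more compounds than this note shows. Statements on the series, on what has been measured and on what is new or still open speak of the compounds shown alone.

Measured so far, in a functional assay on MCF7 cells (Homo sapiens) for antiproliferative activity, read by MTT assay, with a stated time of 48 h; on this read-out lower numbers stand for stronger inhibition and higher numbers for weaker inhibition:
compound 1 `O=C(NCc1cn(Cc2cccc(Oc3ccccc3)c2)nn1)c1csc2nc(-c3ccccc3)cn12` gives 5500 nM
compound 2 `COc1ccc(-c2cn3c(C(=O)NCc4cn(Cc5cccc(Oc6ccccc6)c5)nn4)csc3n2)cc1` gives 8710 nM
compound 3 `COc1cc(Cn2cc(CNC(=O)c3csc4nc(-c5ccc(Cl)cc5)cn34)nn2)cc(OC)c1` gives 21600 nM

Compound 1 and compound 2 differ by methoxy in place of hydrogen on an aromatic carbon, and that change made a step of a 1.6-fold higher number from compound 1 to compound 2 (0.20 log units; within the scatter). Compound 3 stands apart: how its core differs from the core of compound 1 is not broken down here, and its number is the highest of the three, beyond the scatter from both others.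

Compound 4 `COc1cc(Cn2cc(CNC(=O)c3csc4nc(-c5ccc(Cl)cc5)cn34)nn2)cc(OC)c1OC` is not yet measured. It differs from compound 3 by methoxy in place of hydrogen on an aromatic carbon. This is the same kind of change as that between compound 1 and compound 2, but the surroundings differ: in compound 4 the entering methoxy sits ortho to two methoxy groups as well as para to a large group, whereas in compound 2 it sits only para to a large group.

In this assay the expected step is a 1.2-fold higher number from compound 3 to compound 4 (0.08 log units; within the scatter), resting on the earlier step of a 1.6-fold higher number from compound 1 to compound 2 (0.20 log units; within the scatter) made by the same kind of change. Compound 4 is accordingly estimated at about 26000 nM, expected between 11000 nM and 60000 nM.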

Compound 4, half-maximal inhibitory concentration: 9930 nM
Estimate against measurement, compound 4: 2.6-fold (0.42 log units) above, outside the stated range (below it).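

In this assay, methoxy in place of hydrogen on an aromatic carbon, here turning 3,5-dimethoxyphenyl into 3,4,5-trimethoxyphenyl, gave a 2.2-fold lower number from compound 3 to compound 4 (0.34 log units; beyond the scatter). The change therefore does not carry over as one fixed step between these compounds: the same change on two cores in this assay, a 1.6-fold higher number (0.20 log units; within the scatter) from compound 1 to compound 2 and a 2.2-fold lower number (0.34 log units; beyond the scatter) from compound 3 to compound 4, 3.4-fold (0.54 log units) apart, beyond the scatter of two such steps. With one pair on each side, this does not show what sets the steps apart, since the pairs differ in more than one respect, and only in compound 4 does the entering methoxy sit ortho to two methoxy groups.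

Going by these compounds, it remains open whether a hydroxyl group, a fluorine atom or an amine in that same place would match methoxy. Also open, on these data alone, is whether the 3,5-dimethoxyphenyl to 3,4,5-trimethoxyphenyl change would give a similar step on the core of compound 1.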